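This account rests on a few compounds, and the source may have more. Where it says the series, first, only, none or still open, it means among the compounds named here.

Compound 1 `O=c1cc(Cc2c(F)cccc2F)nc(SCc2ccccc2)[nH]1`: in an ADME assay on MT4 cells (Homo sapiens) for cytotoxicity, read by MTT assay (a higher number here means that more compound is tolerated, a lower number that less compound is tolerated), compound 1 gives > 73000 nM, which is a limit of the assay and not a number.
Compound 2 `Cc1c(Cc2c(F)cccc2F)nc(SCc2ccccc2)[nH]c1=O`: in this assay compound 2 gives > 70000 nM, again only a limit.
Compound 3 `O=C(CSc1nc(Cc2c(F)cccc2Cl)cc(=O)[nH]1)c1ccccc1`: in this assay compound 3 gives > 13000 nM, also a limit.

Compound 2 differs from compound 1 by methyl in place of hydrogen on an aromatic carbon. The step that the two limits leave unreadable from compound 1 to compound 2 therefore settles nothing about that change. Compound 4 `Cc1c(Cc2c(F)cccc2Cl)nc(SCC(=O)c2ccccc2)[nH]c1=O` is not yet measured; it differs from compound 3 by methyl in place of hydrogen on an aromatic carbon, the same kind of change, though here the carbon stands ortho to a 2-chloro-6-fluorobenzyl group and para to a large group rather than para to a benzylsulfanyl group. How the core of compound 3 differs from that of compound 1 is not broken down here. Among the measured compounds shown here, what is known is only that compound 3 sits at the limit of > 13000 nM in this assay, at which 1 of the 3 values shown sits, and that a step that the two limits leave unreadable from compound 1 to compound 2 is unreadable. Compound 4 is expected to show a step that the limit leaves unreadable from compound 3 to compound 4 in this assay. Compound 4 is thus estimated at 30000 nM, between 13000 nM and 100000 nM.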

Compound 4, half-maximal cytotoxic concentration: > 12000 nM
Compound 4 ended at the assay's limit; the forecaster's own chance of this, stated with the estimate: 70%; the middle value does not contradict the limit.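

Compound 3 and compound 4 both stop at a limit of the assay, so the size of the step between them cannot be read, and the same holds for compound 1 and compound 2. The compounds shown leave open how much compound any of the four tolerates before cells are harmed in this assay.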